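Aryl swap on the piperazine nitrogen of a thiophene ketone

This account rests on a few compounds, and the source may have more. Where it says the series, first, only, none or still open, it means among the compounds named here.

Measured compounds in a functional assay on CHO cells with adenosine receptor A1 (Homo sapiens) as the target, read by cAMP accumulation and immunoassay, with a stated time of 6 min, tested at 10 uM; a higher number here means a weaker effect of the compound at the concentration tested, a lower number a stronger effect:
compound 1, `CC(C)N1CCN(Cc2csc(N)c2C(=O)c2ccc(Cl)cc2)CC1`, gives -7.4%
compound 2, `Nc1scc(CN2CCN(c3cc(Cl)cc(Cl)c3)CC2)c1C(=O)c1ccc(Cl)cc1`, gives -74%
compound 3, `Nc1scc(CN2CCN(c3ccc(Cl)cc3F)CC2)c1C(=O)c1ccc(Cl)cc1`, gives -81%

Compound 3 holds the lowest of the three numbers in this assay. Its nearest neighbour is compound 2, and the gap between them, a number 7 percentage points lower from compound 2 to compound 3 (within the scatter), lies within the scatter. Compound 1 is far removed: a number 73.6 percentage points lower from compound 1 to compound 3 (beyond the scatter), as is a number 66.6 percentage points lower from compound 1 to compound 2 (beyond the scatter). Both large steps arise where an aryl group replaces the isopropyl on the amine nitrogen in a ring.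

Compound 4, `Nc1scc(CN2CCN(c3ccc(OC(F)(F)F)cc3)CC2)c1C(=O)c1ccc(Cl)cc1`, has not yet been measured. Its change from compound 3 is 4-(trifluoromethoxy)phenyl in place of 4-chloro-2-fluorophenyl on an amine nitrogen in a ring. Going by the values given here, of the measured steps, the one between compound 2 and compound 3 is the closest parallel: there, as here, one aryl group gives way to another on the amine nitrogen in a ring, and that step stayed within the scatter. The two large steps do not apply, as they concern the loss of the isopropyl rather than an aryl-to-aryl exchange. The expected step is therefore a number 9 percentage points higher from compound 3 to compound 4 (within the scatter), nothing beyond the scatter. Compound 4 is estimated to give -72%, in the range -92% to -45%.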

Compound 4, a percentage reported as activity, at one concentration (the size of the read-out at that concentration, not a potency): -74%
Beside the measured number, compound 4's estimate is 2 percentage points above it; the measured number falls inside the stated range.
By their numbers in this assay, from the lowest: compounds 3, 2 and 4 (each within the scatter of the next); then compound 1.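

The 4-(trifluoromethoxy)phenyl group carries an oxygen and no chlorine, yet in this assay the exchange leaves no step beyond the scatter: a number 7 percentage points higher from compound 3 to compound 4 (within the scatter), and no change at the digits printed from compound 2 to compound 4 (within the scatter). Among the three aryl groups shown on this amine nitrogen in a ring, the read-out therefore does not separate a chlorine-bearing ring from one bearing trifluoromethoxy, a point the two chlorine-bearing compounds alone could not make. The large gap to the isopropyl compound also holds for this third aryl group, with a number 66.6 percentage points lower from compound 1 to compound 4 (beyond the scatter).

Nothing available explains these numbers or the gap between the aryl groups and isopropyl. As far as these compounds go, whether the read-out would hold with an unsubstituted phenyl, a benzyl group, or an aryl ring bearing an amine or a carboxylic acid remains open.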